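Trimming the Side Arm: Solubility Expected for Compound 4

This account rests on a few compounds, and the source may have more. Where it says the series, first, only, none or still open, it means among the compounds named here.

Three compounds share one core and were measured in a physicochemical assay for solubility, read by HPLC, with a stated time of 24 h; a higher number here means a more soluble compound, a lower number a less soluble compound:

compound 1 `COC(=O)CC1CCN(C[C@H]2CN(c3ccc(-n4cc(-c5ccccn5)cn4)c(F)c3)C(=O)O2)CC1` gives 92100 nM
compound 2 `O=C1CNC(=O)N1C[C@H]1CN(c2ccc(-n3cc(-c4ccccn4)cn3)c(F)c2)C(=O)O1` gives 1630000 nM
compound 3 `O=C1O[C@@H](CNC(=O)C(F)(F)F)CN1c1ccc(-n2cc(-c3ccccn3)cn2)c(F)c1` gives 114000 nM

Compound 1 stands lowest of the three numbers. Its nearest neighbour is compound 3, since a 1.2-fold higher number from compound 1 to compound 3 (0.09 log units; within the scatter); its furthest is compound 2, since an 18-fold higher number from compound 1 to compound 2 (1.25 log units; beyond the scatter).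

Compound 4 `CNC(=O)[C@H]1CN(c2ccc(-n3cc(-c4ccccn4)cn3)c(F)c2)C(=O)O1` has not been measured. It differs from compound 1 in one place: methylcarbamoyl in place of (4-((methoxycarbonyl)methyl)piperidin-1-yl)methyl on a saturated ring carbon. For the measured compounds named here, two measured steps bear on this change, because each of them also removes the 4-((methoxycarbonyl)methyl)piperidin-1-yl group from compound 1: an 18-fold higher number from compound 1 to compound 2 (1.25 log units; beyond the scatter), whereas a 1.2-fold higher number from compound 1 to compound 3 (0.09 log units; within the scatter). Going by the values given here, the replacement can therefore leave the number where it is or raise it strongly, and no step lowers it.

Compound 4 is thus expected to fall between those outcomes, an estimate of 300000 nM with a range from 80000 nM to 1200000 nM, which would mean an expected 3.3-fold higher number from compound 1 to compound 4 (0.51 log units; beyond the scatter).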

Compound 4, solubility: 26200 nM
For compound 4 the middle estimate is 11-fold (1.06 log units) above the measured one; measured number below the stated range.
By their numbers in this assay, from the lowest: compound 4; then compounds 1 and 3 (each within the scatter of the next); then compound 2.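

In this assay, for the compounds shown here, removing the 4-((methoxycarbonyl)methyl)piperidin-1-yl group no longer leaves the number unchanged or raises it, as it did in the earlier steps: with methylcarbamoyl on the saturated ring carbon there is a 3.5-fold lower number from compound 1 to compound 4 (0.55 log units; beyond the scatter). The same position also gives a 4.4-fold lower number from compound 3 to compound 4 (0.64 log units; beyond the scatter) and a 62-fold lower number from compound 2 to compound 4 (1.79 log units; beyond the scatter), which places compound 4 lowest of the four and shows that a small replacement at this carbon does not by itself raise the number. Nothing available explains these differences.

An (acetylamino)methyl group on this ring carbon would show whether the result follows the methylcarbamoyl group or the loss of the methyl link kept by compounds 1, 2 and 3. On these data alone, how an amine or a carboxylic acid would read at this carbon also remains open.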